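Exchanging the sulfur-linked group on the carbonyl for an aromatic ring

The compounds below may be only part of what the source reports. "The series", "measured", "known", "first", "only" and "open" are said of these compounds alone.

Three compounds share a common core and differ only in the group attached to the carbonyl carbon on the piperidine nitrogen. Compound 1 `Cc1nc(S(C)(=O)=O)ccc1Oc1ncnc(OC2CCN(C(=O)OC(C)C)CC2)c1F` gives 21 nM in a functional assay on isolated protein for inhibition of Glucose-dependent insulinotropic receptor (Homo sapiens), read by HTRF and cAMP accumulation (on this read-out higher numbers stand for an effect only at larger amounts of compound and lower numbers for an effect already at smaller amounts), compound 2 `Cc1nc(S(C)(=O)=O)ccc1Oc1ncnc(OC2CCN(C(=O)O[C@@H](C)CF)CC2)c1F` gives 186 nM, and compound 3 `Cc1nc(S(C)(=O)=O)ccc1Oc1ncnc(OC2CCN(C(=O)SC(C)(C)C)CC2)c1F` gives 4.83 nM, the lowest of the three numbers. The measured steps show that this carbonyl substituent matters: an 8.9-fold higher number from compound 1 to compound 2 (0.95 log units; beyond the scatter), a 4.3-fold lower number from compound 1 to compound 3 (0.64 log units; beyond the scatter) and a 39-fold lower number from compound 2 to compound 3 (1.59 log units; beyond the scatter).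

Compound 4 `CCc1cnc(C(=O)N2CCC(Oc3ncnc(Oc4ccc(S(C)(=O)=O)nc4C)c3F)CC2)nc1` has not yet been measured. Its difference from compound 3 is 5-ethylpyrimidin-2-yl in place of (tert-butyl)sulfanyl on a carbonyl carbon. Here an aromatic ring with two nitrogen atoms replaces a chain-only group, a kind of change none of the measured steps covers; the known steps only show that changes at this carbonyl carbon move the number by modest to large amounts in either direction. Going by the values given here, with no direct precedent, the expectation for compound 4 is a number near that of compound 3, and the estimate is 10 nM with a range from 2 nM to 60 nM, which would mean an expected step of a 2.1-fold higher number from compound 3 to compound 4 (0.32 log units; beyond the scatter).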

Compound 4, half-maximal effective concentration: 4.7 nM
The estimate for compound 4 lay 2.1-fold (0.33 log units) above the measured number; low and high end bracket the measured number.
By their numbers in this assay, from the lowest: compounds 4 and 3 (each within the scatter of the next); then compound 1; then compound 2.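

In this assay a ring can stand on this carbonyl carbon in place of a chain with no change beyond the scatter: a 1.0-fold lower number from compound 3 to compound 4 (0.01 log units; within the scatter) is all that separates them, even though 5-ethylpyrimidin-2-yl brings one six-membered aromatic ring where (tert-butyl)sulfanyl had no ring. A sulfur link on the carbonyl is thus not required for a low number, and the pyrimidine matches the thioester's lead over the oxygen-linked groups, with a 4.5-fold lower number from compound 1 to compound 4 (0.65 log units; beyond the scatter) and with a 40-fold lower number from compound 2 to compound 4 (1.60 log units; beyond the scatter) as well. No data at hand explain why two such different groups read alike.

From the compounds shown here alone, it remains open whether the ethyl group matters, which pyrimidin-2-yl without it would test. Also open, going by these compounds, is how a plain phenyl ring or a dimethylamino group would fare on this carbonyl carbon.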